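The compounds below may be only part of what the source reports. "The series", "measured", "known", "first", "only" and "open" are said of these compounds alone.

The series shares one core, shown in compound 1 `Fc1ccc2nc(-c3cn[nH]c3)n(C3CC3)c2c1`, compound 2 `Cc1ncncc1-c1nc2cc(F)c(F)cc2n1C1CC1` and compound 3 `CNc1ncncc1-c1nc2cc(F)c(F)cc2n1C1CC1`, and the unmeasured compound 4 `CC(F)(F)c1ncncc1-c1nc2cc(F)c(F)cc2n1C1CC1` is built on the same frame. In an assay on cells for inhibition of cytochrome P450 11B2, mitochondrial (Homo sapiens), read by HPLC, with a stated time of 90 min (a lower number here means a stronger inhibitor, a higher number a weaker inhibitor), compound 1 gives 782 nM, and compound 2 gives 17 nM. For compound 3 the assay returns only a limit, < 2 nM, so its true number is not known; this is the limit of < 2 nM in this assay, at which 1 of the 3 values shown sits. The step of an at least 8.5-fold lower number from compound 2 to compound 3 (0.92 log units; beyond the scatter) is therefore the clearest signal in the data: exchanging a methyl for a methylamino sharpened inhibition by a margin beyond the scatter, though its full extent is hidden by the limit.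

Compound 4 is reached from compound 3 by 1,1-difluoroethyl in place of methylamino on an aromatic carbon. Among the measured compounds shown here, no measured pair carries a 1,1-difluoroethyl, so the only guide is that compound 2, with a plain methyl at this position, sits at 17 nM. Compound 3, with methylamino at this position, returns only a limit of the assay. Since the methylamino that drove the step from compound 2 to compound 3 is removed, the expected direction for compound 4 is a higher number than compound 3, and the estimated step is an at least 10-fold higher number from compound 3 to compound 4 (1.00 log units; beyond the scatter). Compound 4 is accordingly expected to give 20 nM, in a range from 5 nM to 80 nM.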

Compound 4, half-maximal inhibitory concentration: 50 nM
Estimate against measurement, compound 4: 2.5-fold (0.40 log units) below; the measured number falls inside the stated range.
By their numbers in this assay, from the lowest: compound 2; then compound 4; then compound 1. At a limit, below all of these: compound 3.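

Exchanging the methylamino for 1,1-difluoroethyl gives an at least 25-fold higher number from compound 3 to compound 4 (1.39 log units; beyond the scatter), so at this position the gain seen with methylamino does not carry over to a group that has 0 hydrogen-bond donors and 0 hydrogen-bond acceptors. Measured against the plain methyl, the same group gives a 2.9-fold higher number from compound 2 to compound 4 (0.47 log units; beyond the scatter), which marks the two groups without nitrogen as much closer to each other than either is to the methylamino, though the gap between them still lies beyond the scatter. The step away from compound 3 is only a lower bound, since compound 3 stands at a limit and the full size of the step stays hidden: the limit of < 2 nM in this assay, at which 1 of the 4 values shown sits.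

The compounds shown leave open which part of the methylamino carries the gain: the nitrogen on the ring, the hydrogen on that nitrogen, or the methyl attached to it. An unsubstituted amine, a dimethylamino or a methoxy group at this position would separate these, and an ethyl group would show whether the two fluorines of the 1,1-difluoroethyl play any part in the difference between compound 2 and compound 4.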